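The source may report more compounds than this note shows. Statements on the series, on what has been measured and on what is new or still open speak of the compounds shown alone.

Measured so far:
compound 1, `C=C[C@@](C)(/C=C/c1ccc(OCc2ccccc2)cc1)CCC=C(C)C`: > 43400 nM
compound 2, `C=C[C@@](C)(/C=C/c1ccc(O)cc1)CCC(O)C(C)(C)O`: > 43400 nM

In a functional assay on NALM-6 cells (Homo sapiens) for cytotoxicity, with a stated time of 72 h (a lower number here means that less compound is needed, a higher number that more compound is needed for the effect), compound 1 gives only a limit, > 43400 nM. In this assay compound 2 likewise returns a limit, > 43400 nM. For the measured compounds named here, both readings sit at the limit of > 43400 nM in this assay, at which 2 of the 2 values shown sit, so compound 2 stands at the limit with no number of its own, and the one other value shown is a limit as well. Going by the values given here, the two measured compounds differ in more than one place, so no single step between them can be read.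

Compound 3, `C=C[C@@](C)(/C=C/c1ccc(O)cc1)CC/C=C(C)/C=N/N`, differs from compound 2 in one place: a group of 6 heavy atoms (4 carbon, 2 nitrogen; no ring) in place of a group of 6 heavy atoms (4 carbon, 2 oxygen; no ring), on a saturated chain carbon, three bonds along the chain from two double-bonded chain carbons. Nothing in the measured pair points toward a gain, and the expected step of an at least 1.0-fold lower number from compound 2 to compound 3 (0.03 log units; that floor lies within the scatter) is none beyond the scatter, with another limit the most likely outcome. Compound 3 is therefore expected near 40000 nM, within 10000 nM to 100000 nM.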

Compound 3, half-maximal effective concentration: > 43400 nM
Compound 3 gave a limit, no number (the forecaster's own chance of this, stated with the estimate: 60%); middle value at least 1.0-fold (0.03 log units) away from the limit.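

In this assay, compound 3 gives only a limit, as compound 2 does, so no step between the two can be read: the limit of > 43400 nM in this assay, at which 3 of the 3 values shown sit.

The compounds shown leave open which change to the shared core, if any, would give a measured number rather than a limit in this assay.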